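Trifluoromethyl at the fluoro site of compound 3

The source may report more compounds than this note shows. Statements on the series, on what has been measured and on what is new or still open speak of the compounds shown alone.

Measured compounds, with their numbers in an assay on NIH3T3 cells for inhibition of Sonic hedgehog protein (Mus musculus), read by a luciferase reporter, with a stated time of 48 h; on this read-out higher numbers stand for weaker inhibition and lower numbers for stronger inhibition:
- compound 1, `Cc1ccccc1C(=O)Nc1ccc(Nc2ncc(C)c(-c3ccc(OC(F)(F)F)cc3)n2)cc1`, gives 42.1 nM
- compound 2, `Cc1cnc(Nc2ccc(C(=O)Nc3c(C)cccc3C)cc2)nc1-c1ccc(OC(F)(F)F)cc1`, gives 1.3 nM
- compound 3, `Cc1cccc(C)c1NC(=O)c1ccc(Nc2ncc(F)c(-c3ccc(OC(F)(F)F)cc3)n2)cc1`, gives 1.6 nM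

Compound 3 stands second of the three numbers in this assay; its nearest neighbour is compound 2, from which it is separated only within the scatter, while compound 1 sits far above it. The two measured steps are of very different size: a 32-fold lower number from compound 1 to compound 2 (1.51 log units; beyond the scatter), a large step tied to the amide rearrangement on the shared core, and a 1.2-fold higher number from compound 2 to compound 3 (0.09 log units; within the scatter), a step that leaves the number unchanged within the scatter.

Compound 4, `Cc1cccc(C)c1NC(=O)c1ccc(Nc2ncc(C(F)(F)F)c(-c3ccc(OC(F)(F)F)cc3)n2)cc1`, differs from compound 3 in one place: trifluoromethyl in place of fluoro on an aromatic carbon. Going by the values given here, only the step from compound 2 to compound 3 bears on this change, since it exchanges small groups at the same place, and that step was within the scatter. No measured step covers trifluoromethyl at this place, so the size of any effect is not shown. The expectation is therefore a step near the scatter in this assay, with no clear direction, and compound 4 is estimated to give 2.5 nM, within 0.8 nM to 8 nM, corresponding to an expected 1.6-fold higher number from compound 3 to compound 4 (0.19 log units; within the scatter).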

Compound 4, half-maximal inhibitory concentration: 0.53 nM
For compound 4 the middle estimate is 4.7-fold (0.67 log units) above the measured one; measured number outside the range, below it.
By their numbers in this assay, from the lowest: compound 4; then compounds 2 and 3 (each within the scatter of the next); then compound 1.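

In this assay the aromatic carbon ortho to the 4-(trifluoromethoxy)phenyl group turns out to respond to its substituent: trifluoromethyl in place of fluoro gives a 3.0-fold lower number from compound 3 to compound 4 (0.48 log units; beyond the scatter), and trifluoromethyl in place of methyl gives a 2.5-fold lower number from compound 2 to compound 4 (0.39 log units; beyond the scatter), whereas the exchange of methyl for fluoro, a 1.2-fold higher number from compound 2 to compound 3 (0.09 log units; within the scatter), had suggested a flat position. Methyl and fluoro therefore do not mark the limit of what this carbon accepts, since trifluoromethyl, with 4 heavy atoms against 1 for fluoro, is tolerated and brings a modest further drop in the number. No evidence at hand bears on why this step occurs.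

On these data alone, it remains open whether the drop is particular to trifluoromethyl, or whether a chlorine, a nitrile, an ethyl chain or a plain hydrogen on this carbon would fall on the same side of compound 2 and compound 3. Also open, as far as these compounds go, is whether the step would carry over to a compound bearing the ((2-methylphenyl)carbonyl)amino group of compound 1 rather than the (2,6-dimethylphenyl)carbamoyl group.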